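Replacing 3-hydroxyphenyl with 4-fluorophenyl: compound 1 to compound 4

This account rests on a few compounds, and the source may have more. Where it says the series, first, only, none or still open, it means among the compounds named here.

In a functional assay on A549/CDDP cells (Homo sapiens) for antiproliferative activity, read by MTT assay, with a stated time of 72 h (a higher number here means a weaker inhibitor, a lower number a stronger inhibitor), compound 1 `Cc1nc(C)c(/C=C/C(=O)/C=C/c2cccc(O)c2)nc1C` gives 3700 nM, compound 2 `COc1cccc(/C=C/C(=O)/C=C/c2nc(C)c(C)nc2C)c1` gives 3440 nM and compound 3 `COc1ccc(/C=C/C(=O)/C=C/c2nc(C)c(C)nc2C)c(OC)c1` gives 2850 nM. Compound 1 therefore stands level with the other two, as its gaps to both lie within the scatter.

Compound 4 `Cc1nc(C)c(/C=C/C(=O)/C=C/c2ccc(F)cc2)nc1C` departs from compound 1 in one place: 4-fluorophenyl in place of 3-hydroxyphenyl on a double-bonded chain carbon bound to a double-bonded chain carbon.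

Among the measured compounds shown here, the only measured step that bears on this change is a 1.1-fold lower number from compound 1 to compound 2 (0.03 log units; within the scatter), with methyl in place of hydrogen on an oxygen on an aromatic ring. That step lies within the scatter, and it alters the 3-hydroxyphenyl group without removing it. For the measured compounds named here, no measured compound carries fluorine, so the guide is only partial. In this assay no shift beyond the scatter is expected, and no direction can be firmly assigned. The estimate is a 1.2-fold lower number from compound 1 to compound 4 (0.09 log units; within the scatter), which is expected to stay within the scatter. Compound 4 is expected at 3000 nM, with an estimated range of 1300 nM to 7000 nM.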

Compound 4, half-maximal inhibitory concentration: 7440 nM
The estimate for compound 4 lay 2.5-fold (0.39 log units) below the measured number; the whole stated range lies below it.
By their numbers in this assay, from the lowest: compounds 3, 2, 1 and 4 (each within the scatter of the next, the first and the last beyond it).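

In this assay, the change gives a 2.0-fold higher number from compound 1 to compound 4 (0.30 log units; within the scatter), so exchanging 3-hydroxyphenyl for 4-fluorophenyl on a double-bonded chain carbon bound to a double-bonded chain carbon leaves the number within the scatter, though the step is printed at its full reach. The earlier step altered only the hydrogen on the oxygen, whereas this one removes that oxygen and shows that a ring with 0 hydrogen-bond donors and 0 hydrogen-bond acceptors can stand here without a shift beyond the scatter. Nothing available explains this result.

Since the group's substituent and its ring location change together, 3-fluorophenyl and 4-hydroxyphenyl would be needed to separate the two. On these data alone, whether an amine or a carboxylic acid on this phenyl ring would move the number beyond the scatter remains open.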